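Compound 1 gains a chain on its amino nitrogen

This account rests on a few compounds, and the source may have more. Where it says the series, first, only, none or still open, it means among the compounds named here.

Measured in a functional assay on the whole organism for inhibition, with Mus musculus as the target; on this read-out higher numbers stand for an effect only at larger amounts of compound and lower numbers for an effect already at smaller amounts:
Compound 1 `CN1Cc2c(N)cccc2C(c2ccc(Cl)cc2)C1` gives 1.6 mg/kg
Compound 2 `CN1Cc2c(N)cccc2C(c2ccc(F)cc2)C1` gives about 3.6 mg/kg
Compound 3 `CC(C)c1ccc(C2CN(C)Cc3c(N)cccc32)cc1` gives > 80 mg/kg (a limit, not a number)

Compound 1 has the lowest number of the three, and the nearest gap is a 2.3-fold higher number from compound 1 to compound 2 (0.35 log units; beyond the scatter). Compound 4 `CCNCC(=O)Nc1cccc2c1CN(C)CC2c1ccc(Cl)cc1` keeps the core of compound 1 and changes one place: ((ethylamino)methyl)carbonyl in place of hydrogen on a nitrogen on an aromatic ring. Among the measured compounds shown here, no measured step touches this nitrogen, since all of them swap chloro, fluoro or isopropyl on an aromatic carbon. They bear on it only indirectly: a 2.3-fold higher number from compound 1 to compound 2 (0.35 log units; beyond the scatter) is modest, whereas an at least 50-fold higher number from compound 1 to compound 3 (1.69 log units; beyond the scatter) is large and shows that one change can cost much here. A moderate rise is therefore expected, with wide uncertainty: a 3.1-fold higher number from compound 1 to compound 4 (0.49 log units; beyond the scatter). Compound 4 is estimated at 5 mg/kg, within an expected range from 1 mg/kg to 30 mg/kg.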

Compound 4, dose for half-maximal effect: 24 mg/kg
Beside the measured number, compound 4's estimate is 4.8-fold (0.68 log units) below it; the range from low to high includes it.
By their numbers in this assay, from the lowest: compound 1; then compound 2; then compound 4. At a limit, above all of these: compound 3.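

The amino nitrogen, untouched by the earlier swaps on an aromatic carbon, also responds strongly: in this assay, ((ethylamino)methyl)carbonyl in place of hydrogen gives a 15-fold higher number from compound 1 to compound 4 (1.18 log units; beyond the scatter). Compound 4 still gives a measured number and not a limit, so an effect remains with this chain in place, though only at larger amounts. Nothing shown here explains the rise.

On these data alone, whether the cost lies with the carbonyl or with the ethylamino end stays open. A plain acetyl, a longer chain or a carboxylic acid on this nitrogen could separate the two.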